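Alkyne terminus exchange on the thiazole sulfonamide series

The source may hold more compounds than are shown below. What is called first, only, known or untested is meant among the compounds shown, and "the series" means these compounds.

Measured so far:
- compound 1 `CC(=O)Nc1nc(-c2cccc(NS(=O)(=O)c3ccc(Br)cc3)c2)cs1` — "not active" (no number reported)
- compound 2 `CC(=O)Nc1nc(-c2cccc(NS(=O)(=O)c3ccc(C#C[Si](C)(C)C)cc3)c2)cs1` — 94.3%

In a functional assay on A-375 cells (Homo sapiens) for antiproliferative activity, read by trypan blue exclusion, with a stated time of 48 h, tested at 1 uM (on this read-out higher numbers stand for a weaker effect at the one concentration tested and lower numbers for a stronger effect), compound 1 is reported only as "not active" (no number reported) and carries no number. In this assay, among the compounds with values here, compound 2 gives 94.3%, the only number so far, and on this read-out that stands for a weak effect at the one concentration tested. Within the data shown here, since compound 1 has no number, no step between the two measured compounds can be stated, and there is nothing to gauge the size of a structural change against.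

Compound 3 `CC(=O)Nc1nc(-c2cccc(NS(=O)(=O)c3ccc(C#CCCc4ccccc4)cc3)c2)cs1` is not yet measured. It differs from compound 2 by a group of 8 heavy atoms (8 carbon; one six-membered aromatic ring of carbon only) in place of a group of 4 heavy atoms (3 carbon, 1 silicon; no ring), on a triple-bonded carbon. Among the measured compounds shown here, with no measured step to lean on, the expectation is a step of no more than the usual scatter, if anything toward a slightly stronger effect. The value of compound 3 is estimated at 90%, with a range from 72% to 105%. The step this estimate means, a number 4.3 percentage points lower from compound 2 to compound 3 (within the scatter), is expected to stay within the scatter.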

Compound 3, a percentage reported as activity, at one concentration (the size of the read-out at that concentration, not a potency): 11.5%
Compound 3: the middle estimate sits 78.5 percentage points above what was measured; the measured number lies below the stated range.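

In this assay, within the data shown here, the exchange of the silicon-bearing group for phenethyl on the triple-bonded carbon gives a number 82.8 percentage points lower from compound 2 to compound 3 (beyond the scatter), the first readable step. The group on this triple-bonded carbon is therefore not a silent position: with the rest of the molecule unchanged, this single exchange separates a weak effect from a strong one at the one concentration tested, although that read-out is not a potency. Nothing measured on these compounds accounts for the size of this step.

The exchange alters several things at once, as phenethyl brings an aromatic ring and a larger group, so the compounds shown do not separate the contribution of the ring from that of the chain carrying it; a plain alkyl chain such as n-hexyl, or a phenylpropyl group with a longer chain before the ring, would address that question. Also open, as far as these compounds go, are whether a terminal amine or carboxylic acid on the same chain would be accepted, and how compound 1 relates to the other two, since steps to it cannot be read.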